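Chloro in place of methyl: working notes on the series

The source may report more compounds than this note shows. Statements on the series, on what has been measured and on what is new or still open speak of the compounds shown alone.

Two compounds on the shared core have so far been taken through a functional assay on DERL7 cells (Homo sapiens) for antiproliferative activity, with a stated time of 72 h; on this read-out lower numbers stand for stronger inhibition and higher numbers for weaker inhibition. Going by the values given here, compound 1 `COc1ccc(Cl)cc1-c1[nH]c(-c2ccnc(N)n2)cc1C(N)=O` stands as "not determined" (no result reported), so compound 2 `Cc1ccc(C(F)(F)F)cc1-c1[nH]c(-c2ccnc(N)n2)cc1C(N)=O`, at 640 nM, carries the only number and cannot yet be ranked against another compound.

The next compound is compound 3 `NC(=O)c1cc(-c2ccnc(N)n2)[nH]c1-c1cc(C(F)(F)F)ccc1Cl`, with chloro in place of methyl on an aromatic carbon, ortho to a large group and para to a trifluoromethyl group: chloro in place of methyl on an aromatic carbon.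

Among the compounds with values here, no step between measured compounds exists to set the size or direction of this change. In this assay, no step beyond the scatter is therefore expected, and compound 2 at 640 nM serves as the anchor. The expected change is small, with an estimated 1.3-fold lower number from compound 2 to compound 3 (0.11 log units; within the scatter). For compound 3 the estimated value is 500 nM, with an expected range of 170 nM to 1500 nM.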

Compound 3, half-maximal inhibitory concentration: 1880 nM
Compound 3: the middle estimate sits 3.8-fold (0.58 log units) below what was measured; the measured number lies above the stated range.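

This position, ortho to a large group and para to a trifluoromethyl group, now has its first readable step: in this assay, chloro in place of methyl gives a 2.9-fold higher number from compound 2 to compound 3 (0.47 log units; beyond the scatter), a modest change but one beyond the scatter. The position therefore responds to this exchange of one heavy atom for another, and of the two groups, methyl goes with the lower number on this read-out. Nothing at hand on the series accounts for the step, which stands as an observation only.

On these data alone, whether an ethyl group, fluoro or an amine at this position would read closer to methyl or to chloro remains open. Also open, as far as these compounds go, is whether the step keeps its direction and size when the trifluoromethyl group gives way to a nitrile.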